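N-methylation of the ring amine in a phenylpyridine series

A few compounds are considered here, and "the series" means these few. Any claim that something is new, unique, unknown or untested is made for them only; others in the source may bear on it.

Of the compounds shown here, two have numbers so far in an assay on membranes from brain for displacement of a labelled ligand from Neuronal acetylcholine receptor; alpha4/beta2 (Rattus norvegicus); a lower number here means a stronger inhibitor, a higher number a weaker inhibitor. Compound 1 `CN1C[C@@H]2CN(c3cccnc3)C[C@@H]2C1` gives 26 nM in this assay. Compound 2 `c1ccc(-c2cncc(N3C[C@H]4CNC[C@H]4C3)c2)cc1` gives 0.16 nM in this assay, the lower of the two numbers; its gap to compound 1 lies beyond the usual scatter, and the two structures differ in more than one place, so the two values are reported here without a single step being drawn between them. Compound 3 `CN1C[C@@H]2CN(c3cncc(-c4ccccc4)c3)C[C@@H]2C1` has not yet been measured in this assay. It differs from compound 2 by methyl in place of hydrogen on an amine nitrogen in a ring. Among the compounds with values here, no measured pair shows this change on its own, so its size in this assay is open. On the numbers shown, the step from compound 2 to compound 3 is expected to be a moderate loss, a 5.0-fold higher number from compound 2 to compound 3 (0.70 log units; beyond the scatter), just beyond the scatter. Compound 3 is thus estimated at 0.8 nM in this assay, with a range from 0.25 nM to 3 nM.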

Compound 3, inhibition constant: 51 nM
Estimate against measurement, compound 3: 64-fold (1.80 log units) below; the measured number lies above the stated range.
By their numbers in this assay, from the lowest: compound 2; then compounds 1 and 3 (each within the scatter of the next).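

Within the data shown here, on the amine nitrogen in a ring, methyl in place of hydrogen proves a large loss in this assay (a 320-fold higher number from compound 2 to compound 3 (2.50 log units; beyond the scatter)), the first reading of this change on its own. With methyl on that nitrogen, phenyl in place of hydrogen on an aromatic carbon stays within the scatter (a 2.0-fold higher number from compound 1 to compound 3 (0.29 log units; within the scatter)), so phenyl does not bring compound 3 near the number of compound 2 (0.16 nM). Nothing at hand explains the size of the methyl step.

The compounds shown leave open what phenyl contributes when the ring amine carries hydrogen, as the phenyl step is read only with methyl on that nitrogen. Also open, as far as these compounds go, is how ethyl or a longer chain on that nitrogen would compare with methyl in this assay.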